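Notes on the ring-amide series: octyl to phenyl

The source may hold more compounds than are shown below. What is called first, only, known or untested is meant among the compounds shown, and "the series" means these compounds.

Compound 1 `CCCCCCCCC(=O)N1c2ccccc2CCC1C(=O)Nc1ccccc1C(F)(F)F` gives 7700 nM in a functional assay on HCT-15 cells (Homo sapiens) for cytotoxicity, read by sulforhodamine B assay, with a stated time of 72 h (on this read-out higher numbers stand for weaker inhibition of growth and lower numbers for stronger inhibition of growth), the only number shown for this assay. Compound 2 `O=C(Nc1ccc(O)cc1)C1CCc2ccccc2N1` returns only a limit in this assay, > 100000 nM (the limit of > 100000 nM in this assay, at which 1 of the 2 values shown sits). Compound 3 `O=C(Nc1ccccc1C(F)(F)F)C1CCc2ccccc2N1C(=O)c1ccccc1` differs from compound 1 by phenyl in place of octyl on a carbonyl carbon — phenyl in place of octyl on a carbonyl carbon, or octylcarbonyl to benzoyl one bond further out. Going by the values given here, no measured step covers this change. The step from compound 1 to compound 3 is expected to be a 1.9-fold higher number from compound 1 to compound 3 (0.29 log units; within the scatter), a modest loss beyond the scatter. Compound 3 is estimated at 15000 nM, within 4000 nM to 60000 nM.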

Compound 3, concentration for 50% growth inhibition: 6500 nM
Compound 3: middle estimate off by 2.3-fold (0.36 log units), on the high side; the measured number falls inside the stated range.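

Phenyl in place of octyl on a carbonyl carbon gives a 1.2-fold lower number from compound 1 to compound 3 (0.07 log units; within the scatter) in this assay and so no readable change. Going by these compounds alone, this is the first measured step at this place, and it shows that on the shared core a chain and an aromatic ring can stand there with no difference in growth inhibition. Nothing measured here gives a reason for this sameness.

Left open is whether a shorter chain such as acetyl reads the same on this carbonyl carbon. Also open, from the compounds shown here alone, is whether a benzoyl carrying an amine or a carboxylic acid holds the level of compound 3 6500 nM in this assay or departs from it.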